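Trifluoromethyl removal on the benzyl arm of compound 1

The source may hold more compounds than are shown below. What is called first, only, known or untested is meant among the compounds shown, and "the series" means these compounds.

Compound 1 `N#Cc1cnc(NCc2ccccc2C(F)(F)F)cc1N[C@H]1CC[C@@H](O)CC1` is the anchor of this short series. Among the compounds with values here, in an assay on isolated protein for inhibition of protein kinase C delta type (Homo sapiens), read by TR-FRET, with a stated time of 2 h (a lower number here means a stronger inhibitor, a higher number a weaker inhibitor), compound 1 gives 4500 nM, the only plain number available. Compound 2 `N#Cc1cnc(NCc2ccccc2C(F)(F)F)cc1N[C@H]1CC[C@H](O)CC1` is its mirror image, with both stereocentres on the saturated ring inverted. In this assay compound 2 reaches only a limit, > 10000 nM. The step of an at least 2.2-fold higher number from compound 1 to compound 2 (0.34 log units; beyond the scatter) rests on the limit of > 10000 nM in this assay, at which 1 of the 2 values shown sits, together with the fact that compounds 1 and 2 differ only in the configuration as drawn.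

Compound 3 `N#Cc1cnc(NCc2ccccc2)cc1N[C@H]1CC[C@@H](O)CC1` carries a single change from compound 1: hydrogen in place of trifluoromethyl on an aromatic carbon. None of the measured steps bears on this change; the one step shown, from compound 1 to compound 2, alters configuration alone and keeps the trifluoromethyl in place. No comparison within the series shows what removing the trifluoromethyl does, so the direction is open and the range must be wide. The working expectation for compound 3 is a step of a 1.3-fold higher number from compound 1 to compound 3 (0.12 log units; within the scatter), not beyond the scatter. Compound 3 is accordingly estimated at 6000 nM in this assay, within 1500 nM to 20000 nM.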

Compound 3, half-maximal inhibitory concentration: > 10000 nM
Compound 3 ended at the assay's limit; the forecaster's own chance of this, stated with the estimate: 30%; middle value at least 1.6-fold (0.22 log units) from the limit.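

In this assay, within the data shown here, the trifluoromethyl on the aromatic carbon, ortho to a large group, now has a comparison behind it for the first time: hydrogen in its place gives an at least 2.2-fold higher number from compound 1 to compound 3 (0.34 log units; beyond the scatter), with the configuration of compound 1 kept. The value of compound 3, > 10000 nM, is a limit of the assay. The step therefore fixes a direction and a minimum size but no magnitude, and compound 1 remains the only compound in the series with a plain number, so the reading of this change rests on: the limit of > 10000 nM in this assay, at which 2 of the 3 values shown sit.

Open, as far as these compounds go, is whether the step belongs to trifluoromethyl as such, or whether chlorine, methyl or methoxy on the same aromatic carbon would hold the value of compound 1 or improve on it. Also open, from the compounds shown here alone, is how much further a stronger substituent could take the series from its plain number of 4500 nM for compound 1, for instance with a larger group such as trifluoromethoxy on that carbon.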